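This account rests on a few compounds, and the source may have more. Where it says the series, first, only, none or still open, it means among the compounds named here.

Measured compounds:
Compound 1, `CN(C(=O)NC(=O)c1ccc(Cl)cc1Cl)c1nc(C(F)(F)F)c(C(=O)N/N=C/c2ccc(C(F)(F)F)cc2)s1`, in a functional assay on HepG2 cells (Homo sapiens) for inhibition, read by MTT assay, with a stated time of 72 h (a lower number here means a stronger inhibitor, a higher number a weaker inhibitor), gives 12.4 ug/mL.
Compound 3, `CN(C(=O)NC(=O)c1ccc(F)c(F)c1)c1nc(C(F)(F)F)c(C(=O)N/N=C/c2ccc([N+](=O)[O-])cc2)s1`, gives in this assay 6.23 ug/mL.
Compound 2, `Cc1nc(N(C)C(=O)NC(=O)c2c(F)cccc2F)sc1C(=O)N/N=C/c1ccc(F)cc1`, gives in this assay only a limit, > 100 ug/mL.

Among the measured compounds shown here, compound 2 thus stands at the limit of > 100 ug/mL in this assay, at which 1 of the 3 values shown sits; no number is known for it, only that limit, and among the three measured compounds it is the only one without a number. Compound 4, `Cc1nc(N(C)C(=O)NC(=O)c2c(F)cccc2F)sc1C(=O)N/N=C/c1ccccc1C(F)(F)F`, shares the core of compound 2 and differs from it in one place: 2-(trifluoromethyl)phenyl in place of 4-fluorophenyl on a carbon with a double bond to nitrogen, the change sitting on a carbon with a double bond to nitrogen whose other neighbour is a double-bonded nitrogen. For the measured compounds named here, no step between two measured compounds is available for this change, and compounds 1 and 3 differ from compound 2 in more than this one place, so their values show only that numbers in this range occur.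

From a limit no step size can be computed. The expectation is that compound 4 stays weak, with the step of an at least 1.4-fold lower number from compound 2 to compound 4 (0.15 log units; that floor lies within the scatter) estimated to remain within the scatter or to give at most a modest gain. Compound 4 is estimated at 70 ug/mL, within a range from 20 ug/mL to 200 ug/mL, with a fair chance that this assay again reports only a limit.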

Compound 4, half-maximal inhibitory concentration: 1.11 ug/mL
Beside the measured number, compound 4's estimate is 63-fold (1.80 log units) above it; measured number below the stated range.
By their numbers in this assay, from the lowest: compound 4; then compounds 3 and 1 (each within the scatter of the next). At a limit, above all of these: compound 2.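

In this assay, the group on the carbon with a double bond to nitrogen proves to be a place where a single change can move the number a long way: 2-(trifluoromethyl)phenyl in place of 4-fluorophenyl gives an at least 90-fold lower number from compound 2 to compound 4 (1.95 log units; beyond the scatter). Compound 1 and compound 3 differ from compound 2 in more than this one place, so this step is the only one shown that ties a change to this position alone. Its size is a floor rather than a measured gap, as compound 2 has only a limit: the limit of > 100 ug/mL in this assay, at which 1 of the 4 values shown sits.

From the compounds shown here alone, whether the gain belongs to the trifluoromethyl group itself or to the place it holds on the phenyl ring stays open. Also open, going by these compounds, is how an amine, a carboxylic acid or a methoxy group on that phenyl ring would behave in this assay.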